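Moving a Hydroxyl Around One Arm of Compound 1

The compounds below may be only part of what the source reports. "The series", "measured", "known", "first", "only" and "open" are said of these compounds alone.

Compound 1 `Oc1ccc(-c2cc(-c3ccccc3O)cc(-c3cccc(O)c3)n2)cc1`: 5650 nM
Compound 2 `Oc1ccc(-c2cc(-c3cccc(O)c3)cc(-c3cccc(O)c3)n2)cc1`: 1560 nM
Compound 3 `Oc1ccc(-c2cc(-c3ccccc3O)cc(-c3ccc(O)cc3)n2)cc1`: 780 nM

In an ADME assay on HEK293 cells (Homo sapiens) for cytotoxicity, read by CCK-8 assay, with a stated time of 4 days (on this read-out higher numbers stand for weaker inhibition and lower numbers for stronger inhibition), compound 1 gives the highest number of the three measured, meaning the weakest inhibition of cell growth. Compound 4 `Oc1cccc(-c2cc(-c3ccccc3O)cc(-c3ccccc3O)n2)c1` differs from compound 1 in one place: 2-hydroxyphenyl in place of 4-hydroxyphenyl on an aromatic carbon. Going by the values given here, no measured pair makes exactly this swap, but two steps bear on it. a 3.6-fold lower number from compound 1 to compound 2 (0.56 log units; beyond the scatter), and a 7.2-fold lower number from compound 1 to compound 3 (0.86 log units; beyond the scatter). Each time a 2-hydroxyphenyl gave way to 3-hydroxyphenyl, or a 3-hydroxyphenyl to 4-hydroxyphenyl, the number fell beyond the scatter. The change to compound 4 runs the other way, 4-hydroxyphenyl to 2-hydroxyphenyl, so a rise beyond the scatter, toward weaker inhibition, is expected. For compound 4 the estimate is 17000 nM, within 7000 nM to 40000 nM, an expected step of a 3.0-fold higher number from compound 1 to compound 4 (0.48 log units; beyond the scatter).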

Compound 4, half-maximal inhibitory concentration: 730 nM
Beside the measured number, compound 4's estimate is 23-fold (1.37 log units) above it, outside the stated range (below it).
By their numbers in this assay, from the lowest: compounds 4, 3 and 2 (each within the scatter of the next, the first and the last beyond it); then compound 1.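

Putting 2-hydroxyphenyl in place of 4-hydroxyphenyl next to the ring nitrogen gives a 7.7-fold lower number from compound 1 to compound 4 (0.89 log units; beyond the scatter) in this assay and so means stronger inhibition, the same direction as the two earlier steps away from compound 1. This position therefore tolerates a 2-hydroxyphenyl group without any loss of inhibition, and compound 1 now has the highest number of all four compounds. Nothing shown here explains this direction. Still open, as far as these compounds go, is whether an amine or a methoxy group in place of the hydroxyl on this arm would also lower the number.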